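Isoflavone ether chain lengthening toward a carboxy-terminated tail

The compounds below may be only part of what the source reports. "The series", "measured", "known", "first", "only" and "open" are said of these compounds alone.

Compound 1 `O=c1c(-c2ccc(O)cc2)coc2cc(OCCOCCOCCO)ccc12`: 40 nM
Compound 2 `CCCCCCOc1ccc2c(=O)c(-c3ccc(O)cc3)coc2c1`: 1500 nM

Of the compounds shown here, two have been measured in an assay (Cricetulus griseus) for inhibition of aldehyde dehydrogenase, mitochondrial (Homo sapiens); on this read-out higher numbers stand for weaker inhibition and lower numbers for stronger inhibition. Compound 1 `O=c1c(-c2ccc(O)cc2)coc2cc(OCCOCCOCCO)ccc12` gives 40 nM, while compound 2 `CCCCCCOc1ccc2c(=O)c(-c3ccc(O)cc3)coc2c1` gives 1500 nM, the higher of the two numbers. Within the data shown here, the one step between them, a 38-fold higher number from compound 1 to compound 2 (1.57 log units; beyond the scatter), concerns the same chain on the aromatic oxygen that is now altered again, with butyl in place of 2-(2-hydroxyethoxy)ethoxy.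

Compound 3 `O=C(O)CCCCCCCCCCCCCCCOc1ccc2c(=O)c(-c3ccc(O)cc3)coc2c1` has not yet been measured. Compared with compound 2, the change is 9-carboxynonyl in place of hydrogen on a saturated chain carbon, six bonds along the chain from an oxygen on an aromatic ring. The step from compound 1 to compound 2 is the only one that bears on this change, and it was large. It shows that the composition of this chain matters strongly in this assay, but it does not cover a tail of this length or a 9-carboxynonyl group, so the direction is uncertain. A moderate move toward a lower number is expected for compound 3, a 1.9-fold lower number from compound 2 to compound 3 (0.27 log units; within the scatter), with a wide range. Compound 3 is estimated at 800 nM, between 200 nM and 3000 nM.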

Compound 3, half-maximal inhibitory concentration: > 9000 nM
Compound 3: no number, only a limit; the forecaster's own chance of this, stated with the estimate: 10%; middle value at least 11-fold (1.05 log units) away from the limit.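

In this assay compound 3 gives > 9000 nM and this is a limit of the assay, not a number. The earlier step showed only that the composition of this chain matters, whereas the new one, an at least 6.0-fold higher number from compound 2 to compound 3 (0.77 log units; beyond the scatter) and beyond the scatter, fixes the direction for this change: 9-carboxynonyl in place of hydrogen on a saturated chain carbon, six bonds along the chain from an oxygen on an aromatic ring, goes with weaker inhibition, not stronger. The step gives only a lower bound on the loss, and how far it reaches cannot be told: the limit of > 9000 nM in this assay, at which 1 of the 3 values shown sits.

The compounds shown do not separate the added length of the chain from the carboxy group that 9-carboxynonyl carries, a question that a plain alkyl chain of the same length, or an amine in place of the carboxylic acid, would address. They also leave open how inhibition changes with a shorter carboxy-bearing chain at this place, and whether any such tail can keep inhibition in this assay at all.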